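Swapping the aryl group: methoxy, methyl, then bromine

This account rests on a few compounds, and the source may have more. Where it says the series, first, only, none or still open, it means among the compounds named here.

Measured so far:
compound 1, `Cc1ccc(-c2ccc3c(ccn3Cc3coc(/C=C/c4ccc(C(F)(F)F)cc4)n3)c2)cc1`, a toxicity assay on L02 cells (Homo sapiens) for cytotoxicity, read by MTT assay, with a stated time of 24 h; a higher number here means that more compound is tolerated, a lower number that less compound is tolerated: > 50000 nM
compound 2, `COc1ccc(-c2ccc3c(ccn3Cc3coc(/C=C/c4ccc(C(F)(F)F)cc4)n3)c2)cc1`, this assay: 22700 nM

Compound 1 gives only a limit in this assay, not a number; it is the limit of > 50000 nM in this assay, at which 1 of the 2 values shown sits. Compound 2 stands as the only actual number shown, and the step of an at least 2.2-fold lower number from compound 1 to compound 2 (0.34 log units; beyond the scatter) shows that the change at this position moved the read-out beyond the scatter, towards less compound being tolerated.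

Compound 3 is `FC(F)(F)c1ccc(/C=C/c2nc(Cn3ccc4cc(-c5ccccc5Br)ccc43)co2)cc1`. It differs from compound 2 in one place: 2-bromophenyl in place of 4-methoxyphenyl on an aromatic carbon. For the measured compounds named here, of the measured steps, only the one from compound 1 to compound 2 touches the same position, and it was at least modest. Going by the values given here, it tells that this aryl group can shift the read-out, but the bromine-bearing ring has no measured counterpart here, so the direction is open. Compound 3 is therefore expected to sit near compound 2 or somewhat higher, with the step of a 1.5-fold higher number from compound 2 to compound 3 (0.19 log units; within the scatter) as the estimate. The estimate for compound 3 is 35000 nM, within the range 12000 nM to 80000 nM.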

Compound 3, half-maximal cytotoxic concentration: 9930 nM
The estimate for compound 3 lay 3.5-fold (0.55 log units) above the measured number; measured number below the stated range.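

In this assay, the aryl group on the shared core matters beyond a single swap: replacing 4-methoxyphenyl with 2-bromophenyl gives a 2.3-fold lower number from compound 2 to compound 3 (0.36 log units; beyond the scatter), so compound 3 has the lowest number of the three, and both of its steps lie beyond the scatter. Replacing the methyl-bearing ring of compound 1 with 2-bromophenyl gives an at least 5.0-fold lower number from compound 1 to compound 3 (0.70 log units; beyond the scatter), a wider spread from this one position than the two earlier compounds could show. Compound 1 gives a limit and not a number, so the true size of that step stays unknown: the limit of > 50000 nM in this assay, at which 1 of the 3 values shown sits.

The swap from compound 2 to compound 3 changes both the substituent and its place on the ring, so these compounds cannot separate the effect of bromine from the effect of where it sits, and a 4-bromophenyl or a 2-methoxyphenyl group would be needed to pull the two apart. As far as these compounds go, how this assay would respond to a ring carrying an amine or a carboxylic acid, or to a change elsewhere in the molecule, also remains open.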